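Amine chain shortening on the dicyano series

This account rests on a few compounds, and the source may have more. Where it says the series, first, only, none or still open, it means among the compounds named here.

Measured compounds:
compound 1 `CCN(CC)CCCCn1c(N)c(-c2nc3ccccc3[nH]2)c2nc(C#N)c(C#N)nc21` gives 460 nM in a functional assay on HL-60 cells (Homo sapiens) for antiproliferative activity, read by MTT assay, with a stated time of 48 h; a lower number here means a stronger inhibitor, a higher number a weaker inhibitor
compound 2 `CN(C)CCCCCn1c(N)c(-c2nc3ccccc3[nH]2)c2nc(C#N)c(C#N)nc21` gives 3420 nM in this assay
compound 3 `CCN(CC)CCn1c(N)c(-c2nc3ccccc3n2C)c2nc(C#N)c(C#N)nc21` gives 8800 nM in this assay

Compound 1 gives the lowest number of the three and compound 3 the highest, with compound 2 between them; each gap is beyond the scatter. For the measured compounds named here, the one single-point change that is measured is (dimethylamino)methyl in place of diethylamino on a saturated chain carbon, four bonds along the chain from an aromatic nitrogen, and it reads a 7.4-fold higher number from compound 1 to compound 2 (0.87 log units; beyond the scatter). Compound 3 and compound 1 differ in more than one place, and the difference between the two cores is not broken down here.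

Compound 4 `CN(C)CCCn1c(N)c(-c2nc3ccccc3n2C)c2nc(C#N)c(C#N)nc21` has not been measured. It stands to compound 3 as compound 2 stands to compound 1: (dimethylamino)methyl in place of diethylamino on a saturated chain carbon, two bonds along the chain from an aromatic nitrogen. The place lines are not the same word for word, two bonds along the chain from an aromatic nitrogen in compound 4 against four bonds in compound 2, and the core of compound 3 is not the core of compound 1, so this is the same kind of change rather than the same change.

Going by the values given here, the step from compound 3 to compound 4 in this assay is expected to go the same way, estimated at a 3.4-fold higher number from compound 3 to compound 4 (0.53 log units; beyond the scatter), which rests on the single measured instance a 7.4-fold higher number from compound 1 to compound 2 (0.87 log units; beyond the scatter) and allows for a smaller move given the different place and core. Compound 4 is therefore expected to give about 30000 nM, estimated between 9000 nM and 100000 nM, with a fair chance that this assay returns only a limit for compound 4.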

Compound 4, half-maximal inhibitory concentration: 2120 nM
For compound 4 the middle estimate is 14-fold (1.15 log units) above the measured one; the whole stated range lies above it.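

In this assay the replacement of diethylamino by (dimethylamino)methyl gives a 4.2-fold lower number from compound 3 to compound 4 (0.62 log units; beyond the scatter) and so runs opposite to the earlier step, which means that the direction of this change does not carry from one core to the other in this series: the same change on two cores in this assay, a 7.4-fold higher number (0.87 log units; beyond the scatter) from compound 1 to compound 2 and a 4.2-fold lower number (0.62 log units; beyond the scatter) from compound 3 to compound 4, 31-fold (1.49 log units) apart, beyond the scatter of two such steps

The two steps differ both in the core and in the place of the change, two bonds along the chain from an aromatic nitrogen in one pair and four bonds in the other, so the reversal cannot be assigned to either of these on its own. With one pair on each core, the data show only that the sign of this change cannot be assumed when moving between these two settings; they do not show how large the change would be on any further core or chain.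

Still open, from the compounds shown here alone, is how the 2-(diethylamino)ethyl to 3-(dimethylamino)propyl change reads on the core of compound 1, since that pair would hold the place fixed and vary only the core. Also open, going by these compounds, is how a cyclic amine such as morpholine or pyrrolidine, or a longer chain carrying dimethylamino, would read on the core of compound 3.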